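The source may hold more compounds than are shown below. What is called first, only, known or untested is meant among the compounds shown, and "the series" means these compounds.

The study brings together two compounds measured in an assay on forebrain for inhibition of Monoamine oxidase (Mus musculus); a higher number here means that more compound is needed for the effect, a lower number that less compound is needed. Compound 1 `C=C=CCN(C)Cc1ccccc1` gives 17 umol/kg in this assay. Among the measured compounds shown here, compound 2 `C=C=C(CN)Cc1ccc(OC)cc1` gives 16 umol/kg in this assay, a number that lies within the usual scatter of the one for compound 1, so the two cannot be separated on these data. Compound 3 `C=C=CCNCc1ccccc1` has not yet been measured in this assay. It differs from compound 1 by hydrogen in place of methyl on an amine nitrogen. For the measured compounds named here, no step between two measured compounds is available to guide this change, so the expectation rests on the observation that compound 2, with a differently substituted nitrogen, gives 16 umol/kg close to the number for compound 1. Compound 3 is therefore expected to show a step of a 1.1-fold lower number from compound 1 to compound 3 (0.05 log units; within the scatter) of no more than the scatter, in either direction. The estimate for compound 3 is 15 umol/kg, with a range from 6 umol/kg to 40 umol/kg.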

Compound 3, dose for half-maximal effect: 6 umol/kg
Compound 3: the middle estimate sits 2.5-fold (0.40 log units) above what was measured; low and high end bracket the measured number.
By their numbers in this assay, from the lowest: compound 3; then compounds 2 and 1 (each within the scatter of the next).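

Among the compounds shown here, the amine nitrogen of compound 1 proves to be a position where a single small change registers in this assay: hydrogen in place of methyl gives a 2.8-fold lower number from compound 1 to compound 3 (0.45 log units; beyond the scatter), the first step between measured compounds that differ in one place. The methyl on this nitrogen is therefore not required for the effect in this assay, and losing it moves the number beyond the scatter, although the step is only modest. The data offer no explanation for this step.

From the compounds shown here alone, it remains open whether an ethyl group or a longer chain on this nitrogen would raise the number further or leave it unchanged. Also open, going by these compounds, is whether hydrogen in place of methyl gives a step of similar size on a different core.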